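Ring-to-chain swap on the piperidine nitrogen: compound 4

This account rests on a few compounds, and the source may have more. Where it says the series, first, only, none or still open, it means among the compounds named here.

Measured so far:
compound 1 `COc1cccc(-n2cc3nc(-c4cccnc4C)n(C[C@H]4CCCN(CC5CCO5)C4)c(=O)c3n2)c1` — 23 nM
compound 2 `COc1cccc(-n2cc3nc(-c4cccnc4C)n(C[C@H]4CCCN(CC5CCCCO5)C4)c(=O)c3n2)c1` — 120 nM
compound 3 `COc1cccc(-n2cc3nc(-c4cccnc4C)n(C[C@H]4CCCN(CC5CCC5)C4)c(=O)c3n2)c1` — 1.6 nM

All three share one core and differ only in the group on the amine nitrogen in the ring. In an assay on HEK293 cells for displacement of a labelled ligand from growth hormone secretagogue receptor type 1 (Homo sapiens), with a stated time of 60 min (a lower number here means a stronger inhibitor, a higher number a weaker inhibitor), compound 2 gives the highest number of the three: compound 1 lies a 5.2-fold higher number from compound 1 to compound 2 (0.72 log units; beyond the scatter) away, and compound 3 is the furthest, a 75-fold lower number from compound 2 to compound 3 (1.88 log units; beyond the scatter). Between compound 1 and compound 3 the step is a 14-fold lower number from compound 1 to compound 3 (1.16 log units; beyond the scatter), so the ring carrying an oxygen gives weaker binding than the all-carbon ring of the same size, and the larger oxygen ring weaker still.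

Compound 4 `COC[C@H](C)N1CCC[C@H](Cn2c(-c3cccnc3C)nc3cn(-c4cccc(OC)c4)nc3c2=O)C1` replaces the group on compound 2 as follows: 1-(methoxymethyl)ethyl in place of (oxan-2-yl)methyl on an amine nitrogen in a ring. The new group keeps one oxygen but loses the ring and is smaller than the group it replaces. For the measured compounds named here, no measured step covers an open-chain group here, so the nearest guide is the size trend: the smaller oxygen-containing group of compound 1 sits well below compound 2. A drop in number is therefore expected, of uncertain size, a 4.8-fold lower number from compound 2 to compound 4 (0.68 log units; beyond the scatter). Compound 4 is estimated at 25 nM, with a range of 6 nM to 100 nM.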

Compound 4, half-maximal inhibitory concentration: 1.7 nM
For compound 4 the middle estimate is 15-fold (1.17 log units) above the measured one; the measured number lies below the stated range.
By their numbers in this assay, from the lowest: compounds 3 and 4 (each within the scatter of the next); then compound 1; then compound 2.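

In this assay, the open-chain 1-(methoxymethyl)ethyl group on the amine nitrogen in a ring gives a 71-fold lower number from compound 2 to compound 4 (1.85 log units; beyond the scatter) when it takes the place of (oxan-2-yl)methyl and a 14-fold lower number from compound 1 to compound 4 (1.13 log units; beyond the scatter) when it takes the place of (oxetan-2-yl)methyl, so a group with an oxygen need not sit at the weak end at this position. In place of cyclobutylmethyl, the same group gives a 1.1-fold higher number from compound 3 to compound 4 (0.03 log units; within the scatter), which is within the scatter; compound 4 therefore goes against the link between oxygen and weaker binding suggested by compounds 1 to 3, and that link holds at most for the two oxygen rings. No available evidence bears on the origin of this result.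

The compounds shown leave open whether the low number of compound 4 depends on the ether oxygen, the branching methyl, the absence of a ring or the defined stereocentre. The opposite stereoisomer of 1-(methoxymethyl)ethyl, an unbranched 2-methoxyethyl chain and an all-carbon sec-butyl group would separate these features.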